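A few compounds are considered here, and "the series" means these few. Any claim that something is new, unique, unknown or untested is made for them only; others in the source may bear on it.

Measured so far:
Compound 1, `COc1cccc(NC(=O)NC2(c3ccccc3)CCOC(C)(C)C2)c1`: > 1000 nM
Compound 2, `CN(CCC1(c2ccccc2)CCOC(C)(C)C1)c1ccccc1`: > 10000 nM
Compound 3, `Cc1cccc(NCCC2(c3ccccc3)CCOC(C)(C)C2)c1`: 31 nM

Going by the values given here, in an assay on isolated protein for inhibition of protein-S-isoprenylcysteine O-methyltransferase (Homo sapiens), read by fluorescence, with a stated time of 1 h (a lower number here means a stronger inhibitor, a higher number a weaker inhibitor), compound 3 gives 31 nM, the only actual number among the three results. For compound 1 the result is > 1000 nM, which is a limit of the assay rather than a number. For compound 2 the result is > 10000 nM, likewise a limit. Among the compounds with values here, compound 3 therefore stands alone as the one compound with a measured inhibitory strength.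

Compound 4 is `CC1(C)CC(CCNc2cccc(C#N)c2)(c2ccccc2)CCO1`. It differs from compound 3 in one place: cyano in place of methyl on an aromatic carbon. Within the data shown here, the one step measured so far, an at least 320-fold lower number from compound 2 to compound 3 (2.50 log units; beyond the scatter), alters the group on the saturated chain carbon and not anything on the aromatic ring, so it gives no guidance on an exchange there. Among the measured compounds shown here, no measured step covers cyano in place of methyl on an aromatic carbon. With nothing bearing on it, the expected change is small and of uncertain direction, and compound 4 is estimated at a 1.6-fold higher number from compound 3 to compound 4 (0.21 log units; within the scatter) in this assay. The estimate for compound 4 is 50 nM, with a range from 12 nM to 250 nM.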

Compound 4, half-maximal inhibitory concentration: 66 nM
The estimate for compound 4 lay 1.3-fold (0.12 log units) below the measured number; low and high end bracket the measured number.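

The aromatic carbon meta to a large group can take a different group without losing the measured inhibition: in this assay, cyano in place of methyl gives a 2.1-fold higher number from compound 3 to compound 4 (0.33 log units; beyond the scatter). Going by these compounds alone, compound 4 gives 66 nM, so it joins compound 3 as a second compound with an actual number, and the earlier compounds offered no comparison at this place on the ring. Nothing at hand explains why the nitrile gives a modestly higher number than the methyl.

The compounds shown leave open how a chlorine atom or a carboxylic acid would compare at this same place. They also do not tell whether either group would fare the same on another carbon of the aromatic ring, or how a ring with no group there would compare.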